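Switching the aryl group on a weakly cytotoxic coumarin-triazole ether

The source may hold more compounds than are shown below. What is called first, only, known or untested is meant among the compounds shown, and "the series" means these compounds.

Measured compounds:
Compound 1, `O=c1ccc2cc(OCc3cn(-c4ccccc4Cl)nn3)ccc2o1`: "not determined" (no result reported).
Compound 2, `O=c1ccc2cc(OCc3cn(-c4ccc(Cl)c(Cl)c4)nn3)ccc2o1`: 47800 nM.

Among the measured compounds shown here, compound 2 carries the only number in this set: in a functional assay on HL-60 cells (Homo sapiens) for cytotoxicity, read by MTT assay, with a stated time of 48 h (on this read-out higher numbers stand for weaker inhibition and lower numbers for stronger inhibition), compound 2 gives 47800 nM, a weak result. For the measured compounds named here, compound 1 shares the core but returned no result, so no step between measured compounds is available.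

Compound 3, `O=c1ccc2cc(OCc3cn(-c4ccccc4[N+](=O)[O-])nn3)ccc2o1`, differs from compound 2 in one place: 2-nitrophenyl in place of 3,4-dichlorophenyl on an aromatic nitrogen. Going by the values given here, with no measured step to lean on, a change of the aryl group on the ring nitrogen is expected to move this assay by little, if at all, beyond the usual scatter, and a small weakening is as plausible as a small gain.

Compound 3 is therefore expected to give about 55000 nM in this assay, within 20000 nM to 150000 nM, a step of a 1.2-fold higher number from compound 2 to compound 3 (0.06 log units; within the scatter).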

Compound 3, half-maximal inhibitory concentration: 44600 nM
Compound 3: the middle estimate sits 1.2-fold (0.09 log units) above what was measured; measured number inside the range.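

Among the compounds shown here, the first readable step at this position, 2-nitrophenyl in place of 3,4-dichlorophenyl on the aromatic nitrogen, gives a 1.1-fold lower number from compound 2 to compound 3 (0.03 log units; within the scatter) in this assay. The two aryl groups therefore cannot be told apart on this read-out, even though one carries two chlorine atoms and no hydrogen-bond acceptors and the other a nitro group with 2 hydrogen-bond acceptors. No measurement here explains this outcome.

Compound 1 has no number, so any step involving it cannot be read. Still open, going by these compounds, is whether an amine or a carboxylic acid on the aryl ring, or a longer alkyl chain in place of the aryl group on the aromatic nitrogen, would shift the result in this assay beyond the scatter.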